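The source may report more compounds than this note shows. Statements on the series, on what has been measured and on what is new or still open speak of the compounds shown alone.

Measured so far:
compound 1 `Cc1nnc(SCC(=O)N/N=c2/scc(-c3ccc(F)cc3)n2-c2ccccc2)s1` — in a functional assay on C6 cells (Rattus norvegicus) for cytotoxicity, read by MTT assay, with a stated time of 24 h (on this read-out higher numbers stand for weaker inhibition and lower numbers for stronger inhibition), compound 1 gives 27.3 ug/mL;
compound 2 `Cc1ccc(-c2cs/c(=N/NC(=O)CSc3nnnn3-c3ccccc3)n2-c2ccccc2)cc1` — compound 2 gives 14.7 ug/mL;
compound 3 `COc1ccc(-c2cs/c(=N/NC(=O)CSc3nnc(C)s3)n2-c2ccccc2)cc1` — compound 3 gives 18.7 ug/mL.

Compound 3 holds the second highest of these three numbers, yet its gaps to compound 1 and to compound 2 both lie within the scatter of repeated measurements. Compound 4 `Cc1ccc(-c2cs/c(=N/NC(=O)CSc3nnc(C)s3)n2-c2ccccc2)cc1` differs from compound 3 by methyl in place of methoxy on an aromatic carbon. Within the data shown here, one measured step concerns a change at this aromatic carbon: a 1.5-fold lower number from compound 1 to compound 3 (0.16 log units; within the scatter), which stayed within the scatter. Compound 2 also carries a 4-methylphenyl group but differs elsewhere in the molecule, so only its value can be set beside that of compound 3. The step from compound 3 to compound 4 is therefore expected to stay within the scatter, a 1.0-fold lower number from compound 3 to compound 4 (0.02 log units; within the scatter). In this assay compound 4 is expected to give 18 ug/mL, within 9 ug/mL to 36 ug/mL.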

Compound 4, half-maximal inhibitory concentration: 25.3 ug/mL
Estimate against measurement, compound 4: 1.4-fold (0.15 log units) below; low and high end bracket the measured number.
By their numbers in this assay, from the lowest: compounds 2, 3, 4 and 1 (each within the scatter of the next).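

In this assay, methyl now joins fluoro and methoxy on this aromatic carbon, and neither a 1.4-fold higher number from compound 3 to compound 4 (0.13 log units; within the scatter) nor a 1.1-fold lower number from compound 1 to compound 4 (0.03 log units; within the scatter) leaves the scatter, so the three groups cannot be told apart here. Among these compounds, the change on the sulfur, which no earlier step covered, also stays within the scatter, with a 1.7-fold higher number from compound 2 to compound 4 (0.24 log units; within the scatter) as its size. No supporting measurement bears on these results.

From the compounds shown here alone, whether an amine, a carboxylic acid or a longer alkoxy chain on this aromatic carbon would give a step beyond the scatter remains open. The same question stands for other rings on the sulfur.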